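The source may hold more compounds than are shown below. What is called first, only, known or untested is meant among the compounds shown, and "the series" means these compounds.

Compound 1 `CC1=C(N2CC2)C(=O)C(CC(C)OC(N)=O)=C(N2CC2)C1=O` in a functional assay on L1210 cells (Mus musculus), with a stated time of 1 days (on this read-out higher numbers stand for higher potency (the scale is a negative logarithm) and lower numbers for lower potency), gives 5.86.
Compound 2 `COCCC1=C(N2CC2)C(=O)C(C)=C(N2CC2)C1=O` in this assay gives 5.19.
Compound 3 `CC1=C(N2CC2)C(=O)C(C(C)COC(N)=O)=C(N2CC2)C1=O` in this assay gives 5.93.

Compound 3 has the highest of the three numbers, though its nearest neighbour, compound 1, is within the scatter of it: the step is a number 0.07 log units higher from compound 1 to compound 3 (within the scatter). Only compound 2 is clearly apart, as a number 0.74 log units higher from compound 2 to compound 3 (beyond the scatter) shows.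

Compound 4 `CC(=O)C1=C(N2CC2)C(=O)C(C)=C(N2CC2)C1=O` has not yet been measured. It differs from compound 3 in one place: a group of 3 heavy atoms (2 carbon, 1 oxygen; no ring) in place of a group of 7 heavy atoms (4 carbon, 1 nitrogen, 2 oxygen; no ring), on a double-bonded ring carbon.

Within the data shown here, two measured steps bear on this. Adding the larger chain bearing the carbamate in place of a smaller chain gave a number 0.74 log units higher from compound 2 to compound 3 (beyond the scatter), and removing that carbamate-bearing chain in favour of a smaller one gave a number 0.67 log units lower from compound 1 to compound 2 (beyond the scatter). Both say that the shared core loses potency when the seven-heavy-atom group gives way to a short chain. For compound 4, with the acetyl group in that place, a modest fall in this assay is therefore expected, estimated at a number 0.73 log units lower from compound 3 to compound 4 (beyond the scatter). Compound 4 is estimated to give 5.2 in this assay, with a range from 4.7 to 5.7.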

Compound 4, logarithm of the reciprocal of the active concentration, log(1/C): 3.94
Beside the measured number, compound 4's estimate is 1.26 log units above it; measured number outside the range, below it.
By their numbers in this assay, from the lowest: compound 4; then compound 2; then compounds 1 and 3 (each within the scatter of the next).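

Replacing the carbamate-bearing chains with acetyl on this double-bonded ring carbon gave a number 1.99 log units lower from compound 3 to compound 4 (beyond the scatter) and a number 1.92 log units lower from compound 1 to compound 4 (beyond the scatter) in this assay, so the position tolerates far less than the step to the 2-methoxyethyl compound had suggested. The step of a number 1.25 log units lower from compound 2 to compound 4 (beyond the scatter) adds what the earlier compounds could not show: with no carbamate on either side, the choice of small group at this place still matters greatly, so loss of the carbamate does not account for the whole fall. Nothing available explains why acetyl stands so low.

As far as these compounds go, it remains open whether the carbonyl of acetyl or the shortness of the group drives the fall. An ethyl or a 2-oxopropyl group at this place would help separate the two.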